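The source may report more compounds than this note shows. Statements on the series, on what has been measured and on what is new or still open speak of the compounds shown alone.

Compound 1, with structure `CC(C)Oc1ccc(NC(=O)CSc2nnc(Cc3nn(C)c(=O)c4ccccc34)n2C)cc1`, is the starting point of this step. In an assay on isolated protein (Mus musculus) for inhibition of IL15-IL15 receptor (Homo sapiens), read by resazurin assay, with stated times of 30 min and 2.5 days (a lower number here means a stronger inhibitor, a higher number a weaker inhibitor), compound 1 gives only a limit, > 30000 nM, so its standing rests on a limit and not on a number; this is the limit of > 30000 nM in this assay, at which 1 of the 2 values shown sits. Going by the values given here, the other measured compound, compound 2, with structure `Cn1c(Cc2nn(C)c(=O)c3ccccc23)nnc1S(=O)(=O)CCCCCCCC(=O)Nc1ccc(Br)cc1Br`, gives 1400 nM in this assay, but it differs from compound 1 in more than one place, so the two values show only that one compound reaches a number and the other does not. Compound 3, with structure `Cn1c(Cc2nn(C)c(=O)c3ccccc23)nnc1SCC(=O)Nc1ccc(I)cc1`, is not yet measured. It differs from compound 1 by iodo in place of isopropoxy on an aromatic carbon. With the anchor at a limit, the size of the step cannot be fixed; the expectation is a step of about an at least 1.2-fold lower number from compound 1 to compound 3 (0.07 log units; that floor lies within the scatter), with a fair chance of another limit. Compound 3 is therefore estimated at 25000 nM, within a range from 4000 nM to 100000 nM.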

Compound 3, half-maximal inhibitory concentration: "not active" (no number reported)
Compound 3 has no reported number here; there is nothing to compare the estimate with.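

Going by these compounds alone, compound 3 is reported as not active in this assay, without a number, so no step from compound 1 to compound 3 can be read. Compound 1 itself stands at a limit: the limit of > 30000 nM in this assay, at which 1 of the 3 values shown sits. The compounds shown leave open whether iodo in place of isopropoxy changes inhibition at all.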